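Methoxy-to-hydroxy swap on the biaryl acid arm

The compounds below may be only part of what the source reports. "The series", "measured", "known", "first", "only" and "open" are said of these compounds alone.

The series shares a bicyclic lactam core bearing a cyclopentyl group and a benzyloxy arm carrying a second aromatic ring. In an assay on HEK293 cells for positive allosteric modulation of metabotropic glutamate receptor 2 (Rattus norvegicus), read by thallium flux (a lower number here means a smaller maximal response, a higher number a larger maximal response), compound 1 `O=C1c2ccc(OCc3cccc(-c4ccc(Cl)cc4F)c3)cc2CN1C1CCCC1` gives "not determined" (no result reported), and in this assay compound 2 `O=C1c2ccc(OCc3cccc(-c4ccccc4)c3)cc2CN1C1CCCC1` gives "not determined" (no result reported); nothing further is reported for either. Compound 3 `COc1ccc(C(=O)O)cc1-c1cccc(COc2ccc3c(c2)CN(C2CCCC2)C3=O)c1` is therefore the single point of reference: in this assay compound 3 gives 79.2%, and with two entries lacking a number there is no way to rank it within the series.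

Compound 4 `O=C(O)c1cc(-c2cccc(COc3ccc4c(c3)CN(C3CCCC3)C4=O)c2)ccc1O` keeps the shared core and the benzyloxy arm and differs from compound 3 only in the outer aromatic ring: 3-carboxy-4-hydroxyphenyl in place of 5-carboxy-2-methoxyphenyl on an aromatic carbon. The carboxylic acid remains, the methoxy group is replaced by a hydroxy group, and the ring is still attached at the position meta to a large group.

Among the measured compounds shown here, no measured pair in this set isolates such a change, so the expected step rests on the single value of compound 3 alone. The change is small in size and the acid is retained, so a step from compound 3 to compound 4 of a number 5.2 percentage points lower from compound 3 to compound 4 (within the scatter) is expected, which would remain within the usual scatter. For compound 4 in this assay the estimate is 74%, with a range from 52% to 94%.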

Compound 4, largest response reached (reported as percent of maximum), in percent of the reference or control that the assay uses: 90.1%
Compound 4: the middle estimate sits 16.1 percentage points below what was measured; the range from low to high includes it.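

In this assay, among the compounds shown here, the change to 3-carboxy-4-hydroxyphenyl in place of 5-carboxy-2-methoxyphenyl gives a number 10.9 percentage points higher from compound 3 to compound 4 (beyond the scatter), the first step that can be read, and it shows that the maximal response at this position on the outer ring responds to a change that leaves the carboxylic acid in place. The two group names differ both in the oxygen substituent, methoxy against hydroxy, and in its number on the ring, so this single step covers both differences at once and cannot be assigned to either. Nothing measured here bears on the reason for the step.

Compounds 1 and 2 carry no carboxylic acid and have no reported number, so what the acid contributes to the maximal response cannot be read from this set. Still open, from the compounds shown here alone, are how 3-carboxy-4-methoxyphenyl would compare, which would separate the swap of methoxy for hydroxy from the shift in its ring number, and whether a tetrazole or a methyl ester could stand in for the carboxylic acid.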